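Amide-to-acrylamide exchange on the benzyl arm of compound 1

The source may hold more compounds than are shown below. What is called first, only, known or untested is meant among the compounds shown, and "the series" means these compounds.

Working notes on the series. Compound 1 `CC(C)n1cnc2c(Nc3ccccc3)nc(NCOCc3ccc(C(=O)Nc4ccccc4N)cc3)nc21` carries a (2-aminophenyl)carbamoyl group on its benzyl ring; in a functional assay on HCT-116 cells (Homo sapiens) for antiproliferative activity, read by CCK-8 assay, with a stated time of 72 h, tested at 2 uM (a higher number here means a stronger effect of the compound at the concentration tested, a lower number a weaker effect), compound 1 gives 6.85%. Among the three measured numbers compound 1 stands second highest. Compound 2 `CCCCn1cnc2c(Nc3cccc(Cl)c3)nc(NCOCc3ccc(/C=C/C(=O)Nc4ccccc4N)cc3)nc21` gives 4.76% in this assay, a number within the scatter of that of compound 1, so the two cannot be told apart. Compound 3 `CCC(C)n1cnc2c(NCc3ccc(C(=O)Nc4ccccc4N)cc3)nc(Cl)nc21` differs from compound 1 in several places at once; in this assay compound 3 gives 74.6%, well beyond the scatter above compound 1 and the furthest of the three from it.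

Compound 4 `CC(C)n1cnc2c(Nc3ccccc3)nc(NCOCc3ccc(/C=C/C(=O)Nc4ccccc4N)cc3)nc21` is compound 1 with 2-((2-aminophenyl)carbamoyl)ethenyl in place of (2-aminophenyl)carbamoyl on an aromatic carbon. Within the data shown here, no measured pair differs in this single place, so the size of this step cannot be read from the data. Compound 2 also carries the 2-((2-aminophenyl)carbamoyl)ethenyl group, though other groups differ as well, and compound 2 gives 4.76%, a low number. On that basis the step of a number 1.2 percentage points higher from compound 1 to compound 4 (within the scatter) is expected to stay within the scatter, with no clear direction. For compound 4 the estimate in this assay is 8%, with a range from 0% to 30%.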

Compound 4, a percentage reported as inhibition, at one concentration (the size of the read-out at that concentration, not a potency): 2.53%
Beside the measured number, compound 4's estimate is 5.5 percentage points above it; the range from low to high includes it.
By their numbers in this assay, from the lowest: compounds 4, 2 and 1 (each within the scatter of the next); then compound 3.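

Among these compounds, compound 1 and compound 4 form the first pair that differs in one place only, and a number 4.3 percentage points lower from compound 1 to compound 4 (within the scatter) in this assay, so the two cannot be told apart. At this position, on an aromatic carbon para to a large group, 2-((2-aminophenyl)carbamoyl)ethenyl can therefore stand in place of (2-aminophenyl)carbamoyl without a readable step, although the read-out is low on both sides of the pair, with compound 1 at 6.85% and compound 4 at 2.53%, and a single tested concentration leaves little room to see any further fall. No measurement on hand offers an explanation for this result.

From the compounds shown here alone, it remains open whether the same exchange would give a readable step on the background of compound 3, which gives 74.6% and where the room for a fall is larger. Also open, going by these compounds, is how a hydroxamic acid or a carboxylic acid would read at this place on the ring in the core of compound 1.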